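The source may hold more compounds than are shown below. What is called first, only, known or untested is meant among the compounds shown, and "the series" means these compounds.

Compound 1, `[N-]=[N+]=Nc1nccc2c1ncn2[C@H]1C[C@H](O)[C@@H](CO)O1`, gives 4% in a functional assay (Homo sapiens) for inhibition of Nucleic Acid, tested at 100 uM; a higher number here means more inhibition at the concentration tested (going by the name of the read-out), a lower number less inhibition.
Compound 2, `Clc1[nH]ccc2ncnc1-2`, gives 6% in this assay.
Compound 3, `OC[C@H]1O[C@@H](n2cnc3c(Cl)nccc32)C[C@@H]1O`, gives 5% in this assay.

All three compounds sit at low inhibition in this assay. Compound 2 has the highest of the three numbers, yet its nearest neighbour is compound 3, and that gap is within the scatter; the gap to compound 1 is within the scatter too. Within the data shown here, no compound therefore stands apart from the others. Among the measured compounds shown here, the only step between two measured compounds that differ in one place is a number 1 percentage points higher from compound 1 to compound 3 (within the scatter), a swap of chloro for azido on the larger compounds, not on the core of compound 2, and it stays within the scatter.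

Compound 4, `CNc1[nH]ccc2ncnc1-2`, differs from compound 2 in one place: methylamino in place of chloro on an aromatic carbon. For the measured compounds named here, no measured pair shows methylamino in place of chloro, so no step speaks directly to this change. Going by the values given here, with every measured number close to the others and the one measured step within the scatter, a move beyond the scatter is not expected. Compound 4 is estimated to give about 6%, between -4% and 18%. For compound 4 the expected step is therefore no change at the digits printed from compound 2 to compound 4 (within the scatter).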

Compound 4, a percentage reported as inhibition, at one concentration (the size of the read-out at that concentration, not a potency): 18%
Estimate against measurement, compound 4: 12 percentage points below; the range from low to high includes it.
By their numbers in this assay, from the lowest: compounds 1, 3 and 2 (each within the scatter of the next); then compound 4.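

In this assay, among these compounds, there is a number 12 percentage points higher from compound 2 to compound 4 (beyond the scatter), the only step in this set that lies beyond the scatter, so this aromatic carbon next to the ring nitrogen is a place where changing the group can move the read-out. The earlier swap, a number 1 percentage points higher from compound 1 to compound 3 (within the scatter), could not show this, and it concerned chloro and azido on the larger compounds, whereas here methylamino, with its hydrogen-bond donor and acceptor, replaces chloro on the smaller core, though compound 4 still gives only 18% at the single concentration tested. No measurement shown explains the step, so what methylamino contributes here remains unknown.

A plain amine, dimethylamino or a longer chain such as ethylamino on this same carbon would help show whether the rise depends on the hydrogen on the nitrogen, on the size of the group, or on something else. As far as these compounds go, it also remains open whether methylamino in place of chloro would give a similar step on compound 3, whose larger structure carries the same chloro group.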